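Ring Size on the Aryl Ether Oxygen: Cyclobutyl to Cyclopentyl

The source may hold more compounds than are shown below. What is called first, only, known or untested is meant among the compounds shown, and "the series" means these compounds.

Compound 1, `CCOc1cc(CCc2nc(C)c(CC)s2)nc(NCc2cc(Cl)cc(NC(=O)OC(C)C)c2)c1`: 33 nM
Compound 2, `CCc1sc(CCc2cc(OC(C)C)cc(NCc3cc(Cl)cc(NC(=O)OC(C)C)c3)n2)nc1C`: 12 nM
Compound 3, `CCc1sc(CCc2cc(OC3CCC3)cc(NCc3cc(Cl)cc(NC(=O)OC(C)C)c3)n2)nc1C`: 11 nM

In an assay on cells for binding affinity to Neuropeptide Y receptor type 1 (Homo sapiens) (a higher number here means a weaker inhibitor, a lower number a stronger inhibitor), compound 3 has the lowest of the three numbers. Compound 2 sits very close to it, a 1.1-fold lower number from compound 2 to compound 3 (0.04 log units; within the scatter), while compound 1 lies further away, a 3.0-fold lower number from compound 1 to compound 3 (0.48 log units; beyond the scatter). Compound 4, `CCc1sc(CCc2cc(OC3CCCC3)cc(NCc3cc(Cl)cc(NC(=O)OC(C)C)c3)n2)nc1C`, differs from compound 3 in one place: cyclopentyl in place of cyclobutyl on an oxygen on an aromatic ring. Among the measured compounds shown here, two measured steps concern this oxygen. The step of a 3.0-fold lower number from compound 1 to compound 3 (0.48 log units; beyond the scatter) shows that a bigger group here lowered the number modestly; the step of a 1.1-fold lower number from compound 2 to compound 3 (0.04 log units; within the scatter) shows that swapping isopropyl for cyclobutyl changed almost nothing. One extra ring carbon is therefore expected to move the number little, a 1.1-fold lower number from compound 3 to compound 4 (0.04 log units; within the scatter). Compound 4 is estimated at 10 nM, within a range from 4 nM to 25 nM.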

Compound 4, half-maximal inhibitory concentration: 11 nM
Beside the measured number, compound 4's estimate is 1.1-fold (0.04 log units) below it, and the stated range covers the measured number.
By their numbers in this assay, from the lowest: compounds 3, 4 and 2 (each within the scatter of the next); then compound 1.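

In this assay a five-membered ring on this oxygen does as well as a four-membered one, with (no change at the digits printed from compound 3 to compound 4 (within the scatter)) and, against isopropyl, (a 1.1-fold lower number from compound 2 to compound 4 (0.04 log units; within the scatter)). The advantage over ethyl remains at this larger size, with (a 3.0-fold lower number from compound 1 to compound 4 (0.48 log units; beyond the scatter)), so the three larger groups sit on one level that an extra ring carbon does not leave. Nothing shown here explains that level. Going by these compounds, whether it extends to cyclohexyl, or holds when the ring carries an amine or a hydroxyl, remains open.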